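From a hydroxypentyl chain to a cyclopropyl group

The source may report more compounds than this note shows. Statements on the series, on what has been measured and on what is new or still open speak of the compounds shown alone.

Compound 1 (`C=CCNc1ncnc2c1ncn2[C@H]1C[C@H](N=[N+]=[N-])[C@@H](CO)O1`): > 100000 nM, a limit
Compound 2 (`[N-]=[N+]=N[C@H]1C[C@H](n2cnc3c(NCCCCCO)nc(N)nc32)O[C@@H]1CO`): > 100000 nM, a limit

Both entries come from an ADME assay on CCRF-CEM cells (Homo sapiens) for cytotoxicity, with a stated time of 5 days; on this read-out lower numbers stand for stronger inhibition and higher numbers for weaker inhibition. Compound 2 has no exact number, only the limit > 100000 nM. It shares this position with compound 1, and the overall picture is the limit of > 100000 nM in this assay, at which 2 of the 2 values shown sit. Going by the values given here, no pair of measured compounds yet shows what a single structural change does.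

Compound 3 (`[N-]=[N+]=N[C@H]1C[C@H](n2cnc3c(NC4CC4)nc(N)nc32)O[C@@H]1CO`) has cyclopropyl in place of 5-hydroxypentyl on a nitrogen on an aromatic ring. In this assay, no change beyond the scatter is expected, in either direction. This expectation rests on compound 2, whose reading of > 100000 nM is a limit. The expected step is a number no higher from compound 2 to compound 3 (the limit leaves the size open). For compound 3, the estimated value is 100000 nM, with an expected range from 30000 nM to 300000 nM.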

Compound 3, half-maximal inhibitory concentration: > 100000 nM
Compound 3: a limit, no number; the forecaster's own chance of this, stated with the estimate: 65%; the middle value lies on the limit itself.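

In this assay, compound 2 and compound 3 each give only a limit, not a number, so replacing 5-hydroxypentyl with cyclopropyl yields no readable step: the limit of > 100000 nM in this assay, at which 3 of the 3 values shown sit.

The compounds shown leave open what exact values they would have, and so whether this change has any effect.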